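Adding Fluoro to Compound 3: What Cytotoxicity to Expect

This account rests on a few compounds, and the source may have more. Where it says the series, first, only, none or still open, it means among the compounds named here.

Compound 3 `O=C(NCc1ccccc1)c1c(NO)cc(-c2ccccc2)oc1=O` carries a benzyl group on the amide nitrogen and a plain phenyl on the shared core. In an ADME assay on Huh-7 cells (Homo sapiens) for cytotoxicity, read by a luciferase reporter and WST assay, with a stated time of 3 days (on this read-out lower numbers stand for higher toxicity in this test and higher numbers for lower toxicity in this test), compound 3 gives only a limit, > 20000 nM. Among the values shown, compound 3 is one of the two that sit at the limit of > 20000 nM in this assay, at which 2 of the 3 values shown sit. Compound 1 `O=C(Nc1ccccc1)c1c(NO)cc(-c2ccc(F)cc2)oc1=O`, with a phenyl on the amide nitrogen and a 4-fluorophenyl on the core, gives 10300 nM in this assay. Compound 2 `O=C(NCCO)c1c(NO)cc(-c2ccc(F)cc2)oc1=O`, with a 2-hydroxyethyl on the amide nitrogen, gives only a limit, > 20000 nM. Going by the values given here, the single measured step, an at least 1.9-fold higher number from compound 1 to compound 2 (0.28 log units; that floor lies within the scatter), concerns the amide substituent and not the aromatic ring on the core. Compound 4 `O=C(NCc1ccccc1)c1c(NO)cc(-c2ccc(F)cc2)oc1=O` differs from compound 3 by fluoro in place of hydrogen on an aromatic carbon. Among the compounds with values here, no measured step compares a phenyl with a 4-fluorophenyl on the core; compounds 1 and 2, which both carry the fluorine, give one number and one limit, so they set no direction for this change. The expectation is therefore no step beyond the scatter, with compound 4 most likely remaining at the limit. The step from compound 3 to compound 4 is estimated as a step that the limit leaves unreadable from compound 3 to compound 4. Compound 4 is estimated at 25000 nM, within 12000 nM to 60000 nM.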

Compound 4, half-maximal cytotoxic concentration: > 20000 nM
Compound 4: a limit, no number; the forecaster's own chance of this, stated with the estimate: 70%; the middle value lies beyond the limit too.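

In this assay the change from phenyl to 4-fluorophenyl leaves compound 4 at a limit, as compound 3 is, so the steps to compound 4 from compound 3 and from compound 2 cannot be read. With a benzyl on the amide nitrogen, fluoro at this place, para to a large group, therefore does not bring the value down to a measurable number, and the benzyl swap gives an at least 1.9-fold higher number from compound 1 to compound 4 (0.28 log units; that floor lies within the scatter). Compound 1 remains the only one of the four compounds with a number rather than a limit: the limit of > 20000 nM in this assay, at which 3 of the 4 values shown sit.

From the compounds shown here alone, what the fluoro does to the read-out stays open, since the two compounds that differ by it both give only a limit. Going by these compounds, it is also open whether an amine or a carboxylic acid in place of the fluoro, or a longer chain in place of the benzyl, would give a number in this assay.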